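A few compounds are considered here, and "the series" means these few. Any claim that something is new, unique, unknown or untested is made for them only; others in the source may bear on it.

Measured compounds in an ADME assay (liver) for metabolic stability, with Liver microsome (Rattus norvegicus) as the target, read by LC-MS, using microsomes and NADPH, with stated times of 5 min and 60 min, tested at 4 uM; a higher number here means that more of the compound is left, a lower number that less of the compound is left:
- compound 1, `Cc1c(OCCCCOc2ccc(C(=O)CC(C)(C)C)c(O)c2C)cccc1C(=O)O`: 51%
- compound 2, `Cc1c(OCCCCOc2ccc(C(=O)O)cc2)ccc(C(=O)CC(C)C)c1O`: 66%
- compound 3, `CCCC(=O)c1ccc(OCCCCOc2cc(C(=O)O)ccc2OC)c(C)c1O`: 1%

Compound 3 stands lowest of the three. Its nearest neighbour on the numbers is compound 1, whose value lies well beyond the scatter above it, and compound 2 sits further still, also beyond the scatter. Among the compounds with values here, nothing in the set connects any two of the measured compounds by a single change, so no step in this assay has yet been measured for any one structural alteration, and none of the three gaps can be read as the effect of one group.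

Compound 4, `COc1ccc(C(=O)O)cc1OCCCCOc1ccc(C(=O)CC2CCCC2)c(O)c1C`, has not yet been measured. It is compound 3 with cyclopentyl in place of ethyl on a saturated chain carbon bound to a carbonyl carbon. Everything else in the two structures is the same.

Within the data shown here, no measured pair shows what this change does, so the expectation rests only on where compound 3 stands. Compound 3 gives 1%, the lowest of the three measured numbers. The step from compound 3 to compound 4 is expected to be small, a number 7 percentage points higher from compound 3 to compound 4 (within the scatter), and may not exceed the scatter. Compound 4 is thus expected to give about 8%, within 0% to 30%.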

Compound 4, percent of the compound remaining: 14%
Compound 4: the middle estimate sits 6 percentage points below what was measured; the range from low to high includes it.
By their numbers in this assay, from the lowest: compound 3; then compound 4; then compound 1; then compound 2.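

In this assay, within the data shown here, cyclopentyl in place of ethyl on a saturated chain carbon bound to a carbonyl carbon gives a number 13 percentage points higher from compound 3 to compound 4 (beyond the scatter), the first step that can be read as one change in one place. The earlier compounds shown here differed in several places at once, so they could not show that this position alone can move the read-out beyond the scatter. The same step, read one bond further out, is propyl to cyclopentylmethyl, but nothing available explains the rise from compound 3 to compound 4.

This single pair does not separate the effect of the ring from that of the larger carbon count, so an open chain such as hexyl, or another ring such as cyclohexyl, could show which of the two goes with the step, and an amine on the ring would test whether the position accepts a charged group. The gaps from compound 1 and compound 2 to the other compounds cannot be read as steps, since those compounds differ in more than one place.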